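The compounds below may be only part of what the source reports. "The series", "measured", "known", "first", "only" and "open" are said of these compounds alone.

Compound 1 `CC(C(=O)NCc1ccc(C(F)(F)Cl)nc1N1CCCCC1)c1ccc(NS(C)(=O)=O)c(F)c1` gives 1.3 nM in an assay on CHO cells for antagonist activity at transient receptor potential cation channel subfamily V member 1 (Homo sapiens), read by FLIPR; a higher number here means a weaker inhibitor, a lower number a stronger inhibitor. Compound 2 `CC1CC(C)CN(c2nc(C(F)(F)Cl)ccc2CNC(=O)C(C)c2ccc(NS(C)(=O)=O)c(F)c2)C1` gives 1 nM. Compound 3 `CC(C(=O)NCc1ccc(C(F)(F)Cl)nc1N1CCN(c2ccccc2)CC1)c1ccc(NS(C)(=O)=O)c(F)c1` gives 0.8 nM.

Compound 3 holds the lowest of the three numbers, yet its separation from the others, a 1.6-fold lower number from compound 1 to compound 3 (0.21 log units; within the scatter) and a 1.3-fold lower number from compound 2 to compound 3 (0.10 log units; within the scatter), stays within the scatter, as does a 1.3-fold lower number from compound 1 to compound 2 (0.11 log units; within the scatter). Compound 4 `CC(C(=O)NCc1ccc(C(F)(F)Cl)nc1OC1CCCCC1)c1ccc(NS(C)(=O)=O)c(F)c1` differs from compound 3 by cyclohexyloxy in place of 4-phenylpiperazin-1-yl on an aromatic carbon. From the compounds shown here alone, all three measured steps exchange the group on this same aromatic carbon without moving the number beyond the scatter, which bears on the present change; an oxygen-linked ring in that spot, however, is untested. A small step is therefore expected, a 2.5-fold higher number from compound 3 to compound 4 (0.40 log units; beyond the scatter), toward a somewhat higher number. Compound 4 is expected at 2 nM, within 0.7 nM to 6 nM.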

Compound 4, inhibition constant: 0.9 nM
Compound 4: the middle estimate sits 2.2-fold (0.35 log units) above what was measured, within the range that was stated.
By their numbers in this assay, from the lowest: compounds 3, 4, 2 and 1 (each within the scatter of the next).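

In this assay the picture at this carbon next to the ring nitrogen holds for an oxygen-linked ring: a 1.1-fold higher number from compound 3 to compound 4 (0.05 log units; within the scatter) and a 1.1-fold lower number from compound 2 to compound 4 (0.05 log units; within the scatter) and a 1.4-fold lower number from compound 1 to compound 4 (0.16 log units; within the scatter) all stay within the scatter. The link can thus pass from nitrogen to oxygen, and 4-phenylpiperazin-1-yl can give way to the smaller cyclohexyloxy, with no readable change in the number. No measurement to hand accounts for this flat response.

From the compounds shown here alone, whether a short methoxy, a free amine or a carboxylic acid at this carbon keeps the number stays open. Also open, going by these compounds, is whether a sulfur-linked cyclohexyl ring matches cyclohexyloxy.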